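A few compounds are considered here, and "the series" means these few. Any claim that something is new, unique, unknown or untested is made for them only; others in the source may bear on it.

Of the compounds shown here, three with a shared core have been measured in a functional assay on NCI-H460 cells (Homo sapiens) for inhibition, read by sulforhodamine B assay, with a stated time of 48 h; a higher number here means a weaker inhibitor of growth, a lower number a stronger inhibitor of growth. Compound 1, `COc1cc(-c2cc(/C=C/C(=O)c3ccc(N)cc3)[nH]n2)cc(OC)c1OC`, gives 1800 nM. Compound 2, `COc1ccc(-c2cc(/C=C/C(=O)c3ccc(N)cc3)[nH]n2)cc1`, gives 2070 nM, and compound 3, `COc1cc(C(=O)/C=C/c2cc(-c3cc(OC)c(OC)c(OC)c3)n[nH]2)cc(OC)c1OC`, gives 1890 nM. Compound 1 has the lowest of these three numbers, yet all three sit within the usual scatter of one another, so none of them can be called a stronger or weaker inhibitor of growth than the others on this evidence.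

Compound 4, `COc1cc(-c2cc(/C=C/C(=O)c3ccc(F)c(F)c3)[nH]n2)cc(OC)c1OC`, has not yet been measured. It differs from compound 1 in one place: 3,4-difluorophenyl in place of 4-aminophenyl on a carbonyl carbon. Among the compounds with values here, no step between two measured compounds that differ in a single place is available, so the expectation rests on how little the three measured numbers move across their different substitution patterns. Compound 4 is expected to give a number close to that of compound 1, with the expected step of a 1.4-fold higher number from compound 1 to compound 4 (0.16 log units; within the scatter) most likely staying within the scatter or leaning slightly towards weaker growth inhibition. The estimate for compound 4 is 2600 nM, within an expected range from 900 nM to 8000 nM.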

Compound 4, concentration for 50% growth inhibition: 2960 nM
Compound 4: the middle estimate sits 1.1-fold (0.06 log units) below what was measured; the measured number falls inside the stated range.
By their numbers in this assay, from the lowest: compounds 1, 3, 2 and 4 (each within the scatter of the next).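

Within the data shown here, the pair of compound 1 and compound 4 is the first in this set that differs in one place only, so it gives a direct reading of the group on the carbonyl carbon. In this assay the swap of 4-aminophenyl for 3,4-difluorophenyl gives a 1.6-fold higher number from compound 1 to compound 4 (0.22 log units; within the scatter), so a ring with a hydrogen-bond donor and acceptor can give way to one with neither, with no change that can be told from the scatter. No separate measurement bears on this result.

As far as these compounds go, it remains open whether a carboxylic acid or a nitrile on that phenyl ring, or a methyl group in place of the whole ring, would move the number beyond the scatter. From the compounds shown here alone, it is also open whether this swap would give a similar step with the 4-methoxyphenyl group of compound 2 on the shared core.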